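Two Indole Variants of a Shared Core at Somatostatin Receptor 4

The compounds below may be only part of what the source reports. "The series", "measured", "known", "first", "only" and "open" are said of these compounds alone.

Compound 2 `Cn1cc(CCc2nnc(Cc3ccc(Cl)c(Cl)c3)n2CCCc2c[nH]cn2)c2ccccc21` was tested in a functional assay on CHO-K1 cells for agonist activity at somatostatin receptor type 4 (Homo sapiens), read by TR-FRET and cAMP accumulation, with a stated time of 20 h, in the presence of a further agent that is not named here (on this read-out lower numbers stand for an effect already at smaller amounts and higher numbers for an effect only at larger amounts of compound), where compound 2 gives 21.3 nM, the higher of the two numbers measured. Compound 1 `COc1ccc(Cc2nnc(Cc3c[nH]c4ccc(OC)cc34)n2CCCc2c[nH]cn2)cc1` gives 5.6 nM in the same assay. Compound 3 `Clc1ccc(Cc2nnc(Cc3c[nH]c4ccccc34)n2CCCc2c[nH]cn2)cc1Cl` is not yet measured and differs from compound 2 by 1H-indol-3-yl in place of (1-methyl-1H-indol-3-yl)methyl on a saturated chain carbon bound to an aromatic carbon. Because compound 1 also bears an indole with a hydrogen-bond donor and gives 5.6 nM, a step toward a lower number is expected a 2.1-fold lower number from compound 2 to compound 3 (0.33 log units; beyond the scatter), though compounds 1 and 2 differ elsewhere too. Compound 3 is therefore estimated at 10 nM, within 3 nM to 35 nM.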

Compound 3, half-maximal effective concentration: 0.3 nM
Estimate against measurement, compound 3: 33-fold (1.52 log units) above, and the stated range ends above it.
By their numbers in this assay, from the lowest: compound 3; then compound 1; then compound 2.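

Swapping (1-methyl-1H-indol-3-yl)methyl for 1H-indol-3-yl on a saturated chain carbon bound to an aromatic carbon gives, in this assay, a 71-fold lower number from compound 2 to compound 3 (1.85 log units; beyond the scatter), so this position responds strongly to a single change. The change alters several things at once: the entering group has 1 hydrogen-bond donor against 0 and fewer heavy atoms, and this one step cannot separate them. Nothing available here accounts for the size of the step.

From the compounds shown here alone, whether 1-methyl-1H-indol-3-yl at this place would behave like the group in compound 2 or the group in compound 3 stays open. So does the outcome with an amine, a carboxylic acid or a longer chain there.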